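The source may hold more compounds than are shown below. What is called first, only, known or untested is meant among the compounds shown, and "the series" means these compounds.

Measured in an ADME assay on microsomes from liver (Mus musculus) for metabolic stability; on this read-out lower numbers stand for slow clearance and higher numbers for fast clearance:
compound 1, `COc1cc([C@](O)(CCN(C)C)[C@@H](c2cc3cc(Br)ccc3nc2OC)c2ccnc(OC)c2OC)cc(OC(F)F)n1`, gives 4.9 uL/min;
compound 2, `COc1cc([C@](O)(CCN(C)C)[C@@H](c2cc3cc(C#N)ccc3nc2OC)c2ccnc(OC)c2OC)cc(OC(F)F)n1`, gives 11 uL/min;
compound 3, `COc1cccc([C@H](c2cc3cc(Br)ccc3nc2OC)[C@@](O)(CCN(C)C)c2cc(SC)nc(SC)c2)c1F`, gives 17 uL/min.

Compound 2 differs from compound 1 by cyano in place of bromo on an aromatic carbon, and that change brought a 2.2-fold higher number from compound 1 to compound 2 (0.35 log units; beyond the scatter). Compound 4, `COc1cccc([C@H](c2cc3cc(C#N)ccc3nc2OC)[C@@](O)(CCN(C)C)c2cc(SC)nc(SC)c2)c1F`, is not yet measured in this assay; it differs from compound 3 by cyano in place of bromo on an aromatic carbon, the same change at the same place. How the core of compound 3 differs from that of compound 1 is not broken down here, but compound 3 gives the highest of the three numbers, within the scatter of compound 2 and beyond it relative to compound 1.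

Going by the values given here, because the one measured instance of this change gave a 2.2-fold higher number from compound 1 to compound 2 (0.35 log units; beyond the scatter), a step of similar size is expected from compound 3 to compound 4, namely a 2.1-fold higher number from compound 3 to compound 4 (0.31 log units; beyond the scatter). Compound 4 is therefore estimated at 35 uL/min, with a likely range from 20 uL/min to 60 uL/min.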

Compound 4, intrinsic clearance in a liver preparation (reported as CLH), per the amount of preparation that the assay uses: 20 uL/min
Beside the measured number, compound 4's estimate is 1.8-fold (0.24 log units) above it; measured number inside the range.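

In this assay cyano in place of bromo on an aromatic carbon gave a 1.2-fold higher number from compound 3 to compound 4 (0.07 log units; within the scatter) and so a step that stands within the scatter. Set beside the earlier instance of the change, the two steps cannot be told apart: the same change on two cores in this assay, a 2.2-fold higher number (0.35 log units; beyond the scatter) from compound 1 to compound 2 and a 1.2-fold higher number (0.07 log units; within the scatter) from compound 3 to compound 4, 1.9-fold (0.28 log units) apart, within the scatter of two such steps. The two pairs are thus compatible with the change carrying over between these two cores, but they do not establish a step of fixed size, and on the second core the step alone cannot be told from repeat-measurement noise.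

The compounds shown leave open whether another group on this aromatic carbon, such as chloro, methoxy or an amine, would give a similar number. They also leave open how the change behaves on any other core.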